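Moving the substituent on the benzamide side of compound 1

A few compounds are considered here, and "the series" means these few. Any claim that something is new, unique, unknown or untested is made for them only; others in the source may bear on it.

Measured compounds in a functional assay on HepG2 cells (Homo sapiens) for cytotoxicity, read by MTT assay, with a stated time of 48 h; a higher number here means a weaker inhibitor, a lower number a stronger inhibitor:
compound 1, `O=C(CSc1nc2ccc(NC(=O)c3ccc(Cl)cc3)cc2s1)NCc1ccc(Cl)cc1`, 17800 nM
compound 2, `CNC(=O)CSc1nc2ccc(NC(=O)c3ccc(Cl)cc3)cc2s1`, 15300 nM
compound 3, `O=C(CSc1nc2ccc(NC(=O)c3ccc(Cl)cc3)cc2s1)NCc1ccccc1`, 25400 nM

Compound 1 sits among the three numbers with its value separated from compound 2 by a 1.2-fold lower number from compound 1 to compound 2 (0.07 log units; within the scatter) and from compound 3 by a 1.4-fold higher number from compound 1 to compound 3 (0.15 log units; within the scatter), so none of the three can be set apart from the others in this assay. The step from compound 2 to compound 3 is likewise a 1.7-fold higher number from compound 2 to compound 3 (0.22 log units; within the scatter).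

Compound 4, `COc1ccccc1C(=O)Nc1ccc2nc(SCC(=O)NCc3ccc(Cl)cc3)sc2c1`, differs from compound 1 at the other end of the shared core: 2-methoxyphenyl in place of 4-chlorophenyl on a carbonyl carbon. None of the three measured steps touches this carbonyl carbon; all of them alter the group on the saturated chain carbon bound to the amide-type nitrogen, and each of them stayed within the scatter. Among the measured compounds shown here, there is thus no direct guide for the present change, and the only evidence is that three variations elsewhere on the core left this assay essentially unmoved.

Compound 4 is therefore expected to give a number close to that of compound 1, with the step of a 1.1-fold higher number from compound 1 to compound 4 (0.03 log units; within the scatter) not expected to exceed the scatter. The estimate for compound 4 is 19000 nM, in the range 8000 nM to 45000 nM.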

Compound 4, half-maximal inhibitory concentration: 600 nM
The estimate for compound 4 lay 32-fold (1.50 log units) above the measured number; measured number outside the range, below it.
By their numbers in this assay, from the lowest: compound 4; then compounds 2, 1 and 3 (each within the scatter of the next).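

In this assay, a 30-fold lower number from compound 1 to compound 4 (1.47 log units; beyond the scatter) when 2-methoxyphenyl takes the place of 4-chlorophenyl on the carbonyl carbon, so this end of the molecule can move the number well beyond the scatter, whereas the steps among compounds 1, 2 and 3, all made at the other end, did not. The change combines several differences: the entering group brings an oxygen and a hydrogen-bond acceptor and loses the chlorine, and the substituent's name on the ring changes as well, so this single step cannot assign the drop to any one of these differences. Nothing available bears on why the number falls so far at this position.

A 4-methoxyphenyl or a 2-chlorophenyl group on this carbonyl carbon would separate the identity of the substituent from its place on the ring, and an unsubstituted phenyl group there would give a common reference for both. Going by these compounds, it also remains open whether 2-methoxyphenyl has a comparable effect when the 4-chlorobenzyl group of compound 1 is replaced by the methyl group of compound 2 or the benzyl group of compound 3.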